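The compounds below may be only part of what the source reports. "The series", "measured", "known", "first", "only" and "open" are said of these compounds alone.

Of the compounds shown here, three have so far been measured in a functional assay on Ehrlich cells (Mus musculus) for cytotoxicity, read by trypan blue exclusion, with a stated time of 2 h, tested at 10 ug/mL; on this read-out higher numbers stand for a weaker effect at the one concentration tested and lower numbers for a stronger effect. Compound 1 `CCOc1ccc(NCc2nc3cc(OC)ccc3[n+]([O-])c2-c2ccccc2)cc1` gives 98%, compound 2 `Cc1c(C(=O)N=[N+]=[N-])[n+]([O-])c2cc(Cl)ccc2[n+]1[O-]` gives 88.3%, and compound 3 `COc1ccc2c(c1)[n+]([O-])c(C(=O)N=[N+]=[N-])c(C)[n+]2[O-]` gives 58.3%, the lowest of the three numbers. For the measured compounds named here, the one step that can be read between measured compounds, a number 30 percentage points lower from compound 2 to compound 3 (beyond the scatter), puts methoxy in place of chloro on an aromatic carbon. Compound 4 `COc1ccc2c(c1)[n+]([O-])c(NC(=O)OC(C)C)c(C)[n+]2[O-]` differs from compound 3 in quite another way: a group of 7 heavy atoms (4 carbon, 1 nitrogen, 2 oxygen; no ring) in place of a group of 5 heavy atoms (1 carbon, 3 nitrogen, 1 oxygen; no ring), on an aromatic carbon. Going by the values given here, no measured step involves a change of this kind, so the earlier step gives no direct guide; only the fact that compound 1 and compound 2 both stand higher than compound 3 suggests room for the number to rise. The step is therefore expected to be a number 21.7 percentage points higher from compound 3 to compound 4 (beyond the scatter), with wide uncertainty. Compound 4 is expected to give 80%, between 55% and 100%.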

Compound 4, a percentage reported as activity, at one concentration (the size of the read-out at that concentration, not a potency): 90.4%
Compound 4: the middle estimate sits 10.4 percentage points below what was measured, and the stated range covers the measured number.
By their numbers in this assay, from the lowest: compound 3; then compounds 2, 4 and 1 (each within the scatter of the next).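

In this assay, the change on the aromatic carbon next to the ring nitrogen gives a number 32.1 percentage points higher from compound 3 to compound 4 (beyond the scatter), so on the shared methoxy core this position strongly affects the read-out, and the carbamate-type group gives a much weaker effect at the one concentration tested. Nothing measured here explains this difference.

The compounds shown leave open whether a plain amine or a carboxylic acid at this position would keep the stronger effect of compound 3. They also leave open how the same exchange would behave on the chloro core of compound 2.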